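Three Limits and a Methylphenyl Variant

The compounds below may be only part of what the source reports. "The series", "measured", "known", "first", "only" and "open" are said of these compounds alone.

Compound 1, `COc1ccc(/C=C/C(=O)c2sc(Nc3ccc(Cl)cc3)nc2C)cc1`, gives in a functional assay on PC-3 cells (Homo sapiens) for cytotoxicity, read by MTT assay (on this read-out higher numbers stand for weaker inhibition and lower numbers for stronger inhibition), only a limit, > 25000 nM.
Compound 2, `Cc1ccccc1Nc1nc(C)c(C(=O)/C=C/c2ccc(Cl)cc2)s1`, gives in this assay only a limit, > 25000 nM.
Compound 3, `Cc1nc(Nc2ccc(Cl)cc2)sc1C(=O)/C=C/c1ccc(Cl)cc1`, gives in this assay only a limit, > 25000 nM.

Compound 3 therefore stands nowhere in particular on the numbers shown: its value is a limit of the assay, and so are the two others. Within the data shown here, every value here sits at the limit of > 25000 nM in this assay, at which 3 of the 3 values shown sit, so no compound can be told apart from another, and none can be called weaker or stronger.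

The step to compound 4, `Cc1cccc(Nc2nc(C)c(C(=O)/C=C/c3ccc(Cl)cc3)s2)c1`, is 3-methylphenyl in place of 4-chlorophenyl on a nitrogen on an aromatic ring. Among the measured compounds shown here, two measured steps touch the same kind of change. The step that the two limits leave unreadable from compound 1 to compound 3 and the step that the two limits leave unreadable from compound 2 to compound 3 both run between limits, and neither gives a readable size. Among them, the change from compound 2 to compound 3 also swaps the group on the ring nitrogen, and still nothing emerged from the limit.

With no readable step on record, compound 4 is expected to remain at the limit as well, and the expected step that the limit leaves unreadable from compound 3 to compound 4 is accordingly set at nothing beyond the scatter. Compound 4 is estimated in this assay at 35000 nM, within 8000 nM to 150000 nM.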

Compound 4, half-maximal inhibitory concentration: > 25000 nM
Compound 4 was reported as a limit; the forecaster's own chance of this, stated with the estimate: 85%; the middle value lies beyond the limit too.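

Compound 4 also gives only a limit in this assay, so neither its step from compound 3 nor its step from compound 2 can be read. All four compounds stand at the same limit: the limit of > 25000 nM in this assay, at which 4 of the 4 values shown sit.

The compounds shown leave open how strongly any of them inhibits in this assay, and which change to the shared core would yield a readable value.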